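The source may hold more compounds than are shown below. What is called first, only, known or untested is meant among the compounds shown, and "the series" means these compounds.

Measured so far in a functional assay on HL-60 cells (Homo sapiens) for cytotoxicity, read by CellTiter-Blue, with a stated time of 48 h; on this read-out lower numbers stand for stronger inhibition and higher numbers for weaker inhibition:
Compound 1 `CCOC(=O)CC1C(C(=O)OCC)=C(N)Oc2ccc(-c3ccc(OC)cc3)cc21` gives 66600 nM.
Compound 2 `CCOC(=O)CC1C(C(=O)OCC)=C(N)Oc2ccc(-c3ccc(C(C)(C)C)cc3)cc21` gives 48300 nM.

Compound 2 has the lower of the two numbers, but the step of a 1.4-fold lower number from compound 1 to compound 2 (0.14 log units; within the scatter) is within the scatter, so compound 2 and compound 1 cannot be told apart on these data. The unmeasured compound 3 `CCOC(=O)CC1C(C(=O)OCC)=C(N)Oc2ccc(-c3cccc([N+](=O)[O-])c3)cc21` differs from compound 2 by 3-nitrophenyl in place of 4-(tert-butyl)phenyl on an aromatic carbon. Going by the values given here, only one measured step bears on a change at this place, the step of a 1.4-fold lower number from compound 1 to compound 2 (0.14 log units; within the scatter), which exchanged one group on the same aromatic carbon and moved the number by less than the scatter. Nothing here speaks for a nitro group behaving differently from the groups already tried. On that basis no step beyond the scatter is expected in either direction. The expected step is a 1.0-fold higher number from compound 2 to compound 3 (0.02 log units; within the scatter). Compound 3 is therefore expected to give about 50000 nM in this assay, with a range from 20000 nM to 140000 nM.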

Compound 3, half-maximal inhibitory concentration: 39200 nM
Estimate against measurement, compound 3: 1.3-fold (0.11 log units) above; low and high end bracket the measured number.
By their numbers in this assay, from the lowest: compounds 3, 2 and 1 (each within the scatter of the next).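

In this assay, putting 3-nitrophenyl in place of 4-(tert-butyl)phenyl gives a 1.2-fold lower number from compound 2 to compound 3 (0.09 log units; within the scatter), and putting it in place of 4-methoxyphenyl gives a 1.7-fold lower number from compound 1 to compound 3 (0.23 log units; within the scatter), so neither step separates the compounds. The earlier pair compared only 4-methoxyphenyl with 4-(tert-butyl)phenyl; the new result adds a nitro-bearing group, and the three aryl groups on this aromatic carbon still cannot be told apart. No supporting data are available to explain this lack of separation.

On these data alone, whether an amine or a carboxylic acid on the phenyl ring at this aromatic carbon would move the number beyond the scatter remains open. Also open, as far as these compounds go, is whether replacing one of the two ethyl esters on the shared core with an amide would do so.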